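Chloro to Bromo: a Halogen Swap Without a Measured Precedent

The source may hold more compounds than are shown below. What is called first, only, known or untested is meant among the compounds shown, and "the series" means these compounds.

Of the compounds shown here, three have been measured in a functional assay on MCF7 cells (Homo sapiens) for antiproliferative activity, read by MTT assay, with a stated time of 48 h; on this read-out lower numbers stand for stronger inhibition and higher numbers for weaker inhibition. Compound 1 `Cc1ccc(/C=C/C(=O)Nc2nnc(-c3ccc(Br)cc3)s2)cc1` gives 1.32 ug/mL, compound 2 `O=C(/C=C/c1ccc(C(F)(F)F)cc1)Nc1nnc(-c2ccc(Br)cc2)s1` gives 1.58 ug/mL, and compound 3 `O=C(/C=C/c1ccc(F)cc1)Nc1nnc(-c2ccc(Cl)cc2)s1` gives 1.58 ug/mL. Compound 3 stands level with compound 2 at the digits shown, the pair forming the highest of the three numbers, and its gap to compound 1 lies within the scatter. For the measured compounds named here, the only measured step, a 1.2-fold higher number from compound 1 to compound 2 (0.08 log units; within the scatter), comes from trifluoromethyl in place of methyl on an aromatic carbon and also stays within the scatter.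

Compound 4 `O=C(/C=C/c1ccc(F)cc1)Nc1nnc(-c2ccc(Br)cc2)s1` differs from compound 3 by bromo in place of chloro on an aromatic carbon, sited para to a large group, the same difference one bond further out reading 4-chlorophenyl to 4-bromophenyl. Going by the values given here, no measured step tests this exchange alone. Compound 2, which carries 4-bromophenyl, and compound 3, which carries 4-chlorophenyl, differ in more than one place, yet their numbers sit level. The step for compound 4 is therefore expected to be a 1.1-fold lower number from compound 3 to compound 4 (0.02 log units; within the scatter), nothing beyond the scatter. Compound 4 is estimated at 1.5 ug/mL, with a range from 0.75 ug/mL to 3 ug/mL.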

Compound 4, half-maximal inhibitory concentration: 1.49 ug/mL
Beside the measured number, compound 4's estimate is 1.0-fold (0.00 log units) above it; low and high end bracket the measured number.
By their numbers in this assay, from the lowest: compounds 1, 4, 2 and 3 (each within the scatter of the next).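

Bromo in place of chloro on an aromatic carbon, para to a large group, now has a measured step of its own in this assay: a 1.1-fold lower number from compound 3 to compound 4 (0.03 log units; within the scatter). With 4-bromophenyl held fixed, fluoro also joins trifluoromethyl and methyl as a measured group at the site on the far aromatic ring, with a 1.1-fold lower number from compound 2 to compound 4 (0.03 log units; within the scatter) and a 1.1-fold higher number from compound 1 to compound 4 (0.05 log units; within the scatter), so every exchange tested at either site stays within the scatter. Nothing available explains why these exchanges leave the number so little changed.

The compounds shown leave open whether iodo, an amine or a carboxylic acid at the halogen site would give a step beyond the scatter. They also leave open whether a methoxy group or a longer chain at the site that carries fluoro would do so.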